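Methylating the amine of compound 3

The source may report more compounds than this note shows. Statements on the series, on what has been measured and on what is new or still open speak of the compounds shown alone.

Compound 1 `CC[C@H](NC)C(=O)N[C@@H]1C(=O)N2[C@@H](CC[C@@H]1CN)CC[C@H]2C(=O)NC(c1ccccc1)c1ccccc1`: 51700 nM
Compound 2 `CC[C@H](NC)C(=O)N[C@@H]1C(=O)N2[C@@H](CC[C@@H]1CCNC(=O)c1ccccc1)CC[C@H]2C(=O)NC(c1ccccc1)c1ccccc1`: > 100000 nM (a limit)
Compound 3 `CC[C@H](N)C(=O)N[C@@H]1C(=O)N2[C@@H](CC[C@@H]1CCNC(=O)NCc1ccccc1)CC[C@H]2C(=O)NC(c1ccccc1)c1ccccc1`: > 100000 nM (a limit)

In a functional assay on PC-3 cells (Homo sapiens) for cytotoxicity, read by MTT assay, with a stated time of 96 h (on this read-out higher numbers stand for weaker inhibition and lower numbers for stronger inhibition), compound 3 gives > 100000 nM, which is a limit and not a number. The data at this end are described by the limit of > 100000 nM in this assay, at which 2 of the 3 values shown sit. Compound 4 `CC[C@H](NC)C(=O)N[C@@H]1C(=O)N2[C@@H](CC[C@@H]1CCNC(=O)NCc1ccccc1)CC[C@H]2C(=O)NC(c1ccccc1)c1ccccc1` carries methyl in place of hydrogen on an amine nitrogen, (methyl in place of hydrogen on an amine nitrogen). For the measured compounds named here, no measured step makes this change. The only one, an at least 1.9-fold higher number from compound 1 to compound 2 (0.28 log units; that floor lies within the scatter), lies elsewhere in the molecule and says little here. Compound 2 also carries the methylamino group, and its > 100000 nM is likewise a limit. No step beyond the scatter is therefore expected, in either direction, and the expected change is a number no higher from compound 3 to compound 4 (the limit leaves the size open). For compound 4 the estimate is 100000 nM, with an expected range from 40000 nM to 250000 nM.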

Compound 4, half-maximal inhibitory concentration: 83500 nM
For compound 4 the middle estimate is 1.2-fold (0.08 log units) above the measured one, within the range that was stated.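

In this assay, for the compounds shown here, methyl in place of hydrogen on an amine nitrogen gives an at least 1.1-fold lower number from compound 3 to compound 4 (0.07 log units; that floor lies within the scatter), the first reading of this change, though its size stays open. Benzylamino in place of phenyl on a carbonyl carbon gives an at least 1.1-fold lower number from compound 2 to compound 4 (0.07 log units; that floor lies within the scatter), and the longer substituent on the saturated chain carbon gives a 1.6-fold higher number from compound 1 to compound 4 (0.21 log units; within the scatter), so compound 4 offers a number where its two closest relatives offered only limits or scatter. The high end of the series is still set by a limit: the limit of > 100000 nM in this assay, at which 2 of the 4 values shown sit. As far as these compounds go, whether ethyl on this amine nitrogen would read differently from methyl stays open, as does the effect of a carboxylic acid at the end of the chain.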